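This account rests on a few compounds, and the source may have more. Where it says the series, first, only, none or still open, it means among the compounds named here.

Measured so far in a functional assay on MCF7 cells (Homo sapiens) for antiproliferative activity, read by MTT assay, with a stated time of 48 h; on this read-out lower numbers stand for stronger inhibition and higher numbers for weaker inhibition:
compound 1 `COc1ccc(/C=C/C(=O)Nc2cc3c(Nc4ccc(Cl)c(Cl)c4)ncnc3s2)cc1` gives 20100 nM
compound 2 `COc1ccc(/C=C/C(=O)Nc2cc3c(Nc4cc(Cl)cc(Cl)c4)ncnc3s2)cc1` gives 75600 nM
compound 3 `O=C(/C=C/c1ccccc1)Nc1cc2ncnc(Nc3cc(Cl)cc(Cl)c3)c2s1` gives only a limit of the assay, > 100000 nM

Compounds 1 and 2 share one core and differ in a single place: 3,4-dichlorophenyl in place of 3,5-dichlorophenyl on a nitrogen on an aromatic ring. That change gives a 3.8-fold lower number from compound 2 to compound 1 (0.58 log units; beyond the scatter). For compound 3 the read-out is a limit and not a number, (the limit of > 100000 nM in this assay, at which 1 of the 3 values shown sits). The core of compound 3 differs from the core of compound 2, and that difference is not broken down here.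

Compound 4 `O=C(/C=C/c1ccccc1)Nc1cc2ncnc(Nc3ccc(Cl)c(Cl)c3)c2s1` is not yet measured in this assay. It carries the same change on the core of compound 3, at the same place: 3,4-dichlorophenyl in place of 3,5-dichlorophenyl on a nitrogen on an aromatic ring. The expectation for compound 4 rests on the step of a 3.8-fold lower number from compound 2 to compound 1 (0.58 log units; beyond the scatter), and on compound 3 standing only at its limit > 100000 nM, so the starting point itself is not known. Compound 4 is expected at 60000 nM, within 20000 nM to 150000 nM. The step this estimate means, an at least 1.6-fold lower number from compound 3 to compound 4 (0.22 log units; that floor lies within the scatter), is expected to be of the same kind as the earlier one, though the limit for compound 3 leaves open whether a number will be returned at all.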

Compound 4, half-maximal inhibitory concentration: > 100000 nM
Compound 4 gave a limit, no number; the forecaster's own chance of this, stated with the estimate: 40%; at least 1.6-fold (0.22 log units) between middle value and limit.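

In this assay compound 3 and compound 4 both stand only at a limit of the assay, so no step can be read between them: the limit of > 100000 nM in this assay, at which 2 of the 4 values shown sit.

The compounds shown leave open whether 3,4-dichlorophenyl in place of 3,5-dichlorophenyl changes the read-out on the core of compound 3 as it does on the core of compound 2.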